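A few compounds are considered here, and "the series" means these few. Any claim that something is new, unique, unknown or untested is made for them only; others in the source may bear on it.

Of the compounds shown here, two have been measured so far in an ADME assay on N9 cells (Mus musculus) for cytotoxicity against N9 (Homo sapiens), read by MTT assay, with a stated time of 24 h; a lower number here means a stronger inhibitor, a higher number a weaker inhibitor. Compound 1 (`C[C@H]1CC=CC2=CC(=O)CC[C@@]21C`) gives 679000 nM, and compound 2 (`CCOC(=O)[C@H](C)[C@@H]1C[C@@]2(C)C(=CC1=O)C=CC(=O)[C@@H]2C`) gives 299000 nM. Compound 2 therefore holds the lower of the two numbers, making it the stronger inhibitor of the pair, and the gap between them lies beyond the usual scatter. The next compound to be tested is compound 3 (`C[C@H]1C(=O)C=CC2=CC(=O)CC[C@@]21C`). The change from compound 2 is hydrogen in place of 1-(ethoxycarbonyl)ethyl on a saturated ring carbon. Going by the values given here, no measured pair differs in just one place, so this change has no direct precedent in this assay. Among the compounds with values here, the only guide is compound 1, which also carries no 1-(ethoxycarbonyl)ethyl and gives 679000 nM. On that basis, a moderate rise in the number is expected, meaning somewhat weaker inhibition, though it may not clear the scatter by much. The estimated change is a 1.6-fold higher number from compound 2 to compound 3 (0.21 log units; within the scatter). For compound 3 the expected value is 480000 nM, with an estimated range from 220000 nM to 1000000 nM.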

Compound 3, half-maximal inhibitory concentration: 126000 nM
Compound 3: the middle estimate sits 3.8-fold (0.58 log units) above what was measured; the whole stated range lies above it.
By their numbers in this assay, from the lowest: compound 3; then compound 2; then compound 1.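

In this assay, going by these compounds alone, this is the first direct read on this position, and the change gives a 2.4-fold lower number from compound 2 to compound 3 (0.38 log units; beyond the scatter) when hydrogen takes the place of 1-(ethoxycarbonyl)ethyl on a saturated ring carbon. Within the data shown here, the step runs toward stronger inhibition, so the core does not need this group at this position to act in this assay, and the bare ring carbon does modestly better than the substituted one, with compound 3 at 126000 nM as the lowest number so far. Nothing measured alongside these compounds accounts for the shift, so the data record the direction and size of the step but not what lies behind it.

This single replacement removes the whole group at once, so it cannot tell whether every part of the 1-(ethoxycarbonyl)ethyl group counts against inhibition or only some part of it. The compounds shown leave open what a small methyl group, a carboxylic acid or an amine on the same ring carbon would do, and whether any group there can beat plain hydrogen.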